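The compounds below may be only part of what the source reports. "The series", "measured", "known", "first", "only" and "open" are said of these compounds alone.

In an assay on HEK293 cells for displacement of a labelled ligand from NPC1-like intracellular cholesterol transporter 1 (Homo sapiens) (a higher number here means a weaker inhibitor, a lower number a stronger inhibitor), compound 1 `CC(C)(C)OC(=O)NCCCNC(=O)CN1CN(c2ccccc2)C2(CCN(C(=O)c3ccc(C4CCCCC4)cc3)CC2)C1=O` gives 6000 nM, compound 2 `CC(C)(C)OC(=O)NCCNC(=O)CN1CN(c2ccccc2)C2(CCN(C(=O)c3ccc(C4CCCCC4)cc3)CC2)C1=O` gives 5500 nM, and compound 3 `COC(=O)CCCNC(=O)CN1CN(c2ccccc2)C2(CCN(C(=O)c3ccc(C4CCCCC4)cc3)CC2)C1=O` gives 2500 nM.

Compound 3 stands lowest of the three: a 2.4-fold lower number from compound 1 to compound 3 (0.38 log units; beyond the scatter) and a 2.2-fold lower number from compound 2 to compound 3 (0.34 log units; beyond the scatter) are both beyond the scatter, while a 1.1-fold lower number from compound 1 to compound 2 (0.04 log units; within the scatter) is within it. Compound 4 `NC(=O)C1CCCN(C(=O)CN2CN(c3ccccc3)C3(CCN(C(=O)c4ccc(C5CCCCC5)cc4)CC3)C2=O)C1` differs from compound 3 by 3-carbamoylpiperidin-1-yl in place of (3-(methoxycarbonyl)propyl)amino on a carbonyl carbon. The measured steps all vary the tail of the open chain; none exchanges the chain amine for a ring, so none bears directly on this change, and they were at most modest in size. No step beyond the scatter is expected in this assay . Compound 4 is therefore estimated at 3000 nM, range 1200 nM to 8000 nM, which means an expected step of a 1.2-fold higher number from compound 3 to compound 4 (0.08 log units; within the scatter).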

Compound 4, half-maximal inhibitory concentration: 3100 nM
Beside the measured number, compound 4's estimate is 1.0-fold (0.01 log units) below it; the measured number falls inside the stated range.
By their numbers in this assay, from the lowest: compounds 3, 4, 2 and 1 (each within the scatter of the next, the first and the last beyond it).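

In this assay, 3-carbamoylpiperidin-1-yl on this carbonyl carbon takes the place of the open chains without a step beyond the scatter: a 1.2-fold higher number from compound 3 to compound 4 (0.09 log units; within the scatter), a 1.8-fold lower number from compound 2 to compound 4 (0.25 log units; within the scatter) and a 1.9-fold lower number from compound 1 to compound 4 (0.29 log units; within the scatter). A ring at this position is therefore compatible with binding in the same range as the open chains, so an open chain is not required here. Nothing measured explains this result.

Still open, on these data alone, is whether plain piperidin-1-yl would stay in this range. As far as these compounds go, it is also open whether a carboxylic acid or a primary amine in place of the carbamoyl group would move the number beyond the scatter.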